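A few compounds are considered here, and "the series" means these few. Any claim that something is new, unique, unknown or untested is made for them only; others in the source may bear on it.

- Compound 1 `CNc1cc(Oc2c(OC)cc3cc(C#N)ccc3c2OC)nc(Nc2ccc(C#N)cc2)n1`: 239000 nM
- Compound 2 `COc1cc2cc(C#N)ccc2c(OC)c1Oc1cc(NCC(C)C)nc(Nc2ccc(C#N)cc2)n1`: > 125000 nM (a limit)

Both results come from an ADME assay on MT4 cells (Homo sapiens) for cytotoxicity, read by MTT assay, with a stated time of 5 days; a lower number here means that less compound is tolerated, a higher number that more compound is tolerated. Compound 2 has no exact number here, as its > 125000 nM is a limit of the assay. The next structure, compound 3 `CCCC(C)Nc1cc(Oc2c(OC)cc3cc(C#N)ccc3c2OC)nc(Nc2ccc(C#N)cc2)n1`, differs from compound 2 by one change, 1-methylbutyl in place of isobutyl on a nitrogen on an aromatic ring. Among the measured compounds shown here, the only measured step that bears on this is a step that the limit leaves unreadable from compound 1 to compound 2. Its size cannot be read, so it offers no size to carry over. For the measured compounds named here, the one exact number is that compound 1 gives 239000 nM. With so little to go on, no step beyond the scatter is expected in this assay, and no direction can be named. Compound 3 is expected at about 150000 nM, within an estimated range of 50000 nM to 300000 nM. This estimate means an expected step that the limit leaves unreadable from compound 2 to compound 3.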

Compound 3, half-maximal cytotoxic concentration: > 125000 nM
Compound 3: only a limit was reported (the forecaster's own chance of this, stated with the estimate: 50%); the middle value does not contradict the limit.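

No step can be read among compound 1, compound 2 and compound 3, because compound 2 and compound 3 each carry only a limit: the limit of > 125000 nM in this assay, at which 2 of the 3 values shown sit. Still open, as far as these compounds go, is whether isobutyl, 1-methylbutyl and the methyl of compound 1 differ at all in how much compound the cells tolerate.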